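A few compounds are considered here, and "the series" means these few. Any claim that something is new, unique, unknown or untested is made for them only; others in the source may bear on it.

For the measured compounds named here, in a physicochemical assay for lipophilicity, read by HPLC, at pH 7.5 (a lower number here means a more polar compound, a higher number a more lipophilic compound), compound 1 `CCCCCN(CCCCC)C(=O)Cc1c(-c2ccc(OC)cc2)nn2c(CC)cc(CC)nc12` gives 4.29 and stands highest of the two numbers measured so far, while compound 2 `CCc1cc(CC)n2nc(-c3ccc(OC)cc3)c(CC(=O)N(C)c3ccccc3)c2n1` gives 3.11 on the same scale. Compound 3 `CCc1cc(CC)n2nc(-c3ccc(OC)cc3)c(CC(=O)N3CCC3)c2n1`, still unmeasured, carries azetidin-1-yl in place of dipentylamino on a carbonyl carbon. Going by the values given here, only one measured step bears on this change, a large one at the same place (a number 1.18 log units lower from compound 1 to compound 2 (beyond the scatter)), so a large fall of similar or somewhat greater size is expected in this assay for this change. The estimated step is a number 1.59 log units lower from compound 1 to compound 3 (beyond the scatter) in that direction. Compound 3 is expected to read 2.7 (range 2.2 to 3.2).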

Compound 3, partition coefficient: 2.58
Compound 3: middle estimate off by 0.12 log units, on the high side; measured number inside the range.
By their numbers in this assay, from the lowest: compound 3; then compound 2; then compound 1.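

Azetidin-1-yl on the carbonyl carbon gives a number 1.71 log units lower from compound 1 to compound 3 (beyond the scatter) in this assay, so this place can carry a larger fall than the first step showed. The further a number 0.53 log units lower from compound 2 to compound 3 (beyond the scatter) shows that the two smaller replacements also differ from each other, which leaves compound 3 lowest of the three. No measurement at hand accounts for this order. As far as these compounds go, it remains open whether morpholin-4-yl, with its ring oxygen, or a carboxylic acid on the azetidine ring would read lower still. From the compounds shown here alone, whether the order of these three groups would hold on another core is also open.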